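One Methoxy Group Fewer: What to Expect of Compound 4

The source may report more compounds than this note shows. Statements on the series, on what has been measured and on what is new or still open speak of the compounds shown alone.

Three measured compounds share a core in which two aromatic rings are linked through a carbonyl-bearing chain. Compound 1 `COc1ccc(-c2cc(/C=C/C(=O)c3ccc(N)cc3)[nH]n2)cc1` carries one methoxy group, compound 2 `COc1ccc(-c2cc(/C=C/C(=O)c3ccc(N)cc3)[nH]n2)cc1OC` carries two, and compound 3 `COc1cc(C(=O)/C=C/c2cc(-c3cc(OC)c(OC)c(OC)c3)n[nH]2)cc(OC)c1OC` carries methoxy groups on both rings; the difference between the core of compound 3 and the core of compound 2 is not broken down here.

In a functional assay on OVCAR-3 cells (Homo sapiens) for cytotoxicity, read by sulforhodamine B assay, with a stated time of 48 h, tested at 0.1 uM (on this read-out lower numbers stand for a stronger effect and higher numbers for a weaker effect at the one concentration tested), compound 1 gives 96%, compound 2 gives 108% and compound 3 gives 105%. All three sit close to the untreated level, so none of them shows a strong effect at this concentration. Among the compounds with values here, the only counted change among them is hydrogen in place of methoxy on an aromatic carbon, and it produced a number 12 percentage points lower from compound 2 to compound 1 (beyond the scatter), a modest move.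

Compound 4 `COc1ccc(-c2cc(/C=C/C(=O)c3cc(OC)c(OC)c(OC)c3)[nH]n2)cc1OC` has not yet been measured. It arises from compound 3 by hydrogen in place of methoxy on an aromatic carbon. The surroundings are not identical: in compound 3 the site is also meta to a methoxy group, so this is the same kind of change, not the same one.

In this assay compound 4 is expected to give about 98%, most likely between 85% and 110%. This estimate means a number 7 percentage points lower from compound 3 to compound 4 (within the scatter), a step expected to be small, resting on the earlier step of a number 12 percentage points lower from compound 2 to compound 1 (beyond the scatter) and on compound 3 already standing at 105%, which leaves little room for a large move.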

Compound 4, a percentage reported as activity, at one concentration (the size of the read-out at that concentration, not a potency): 100%
For compound 4 the middle estimate is 2 percentage points below the measured one, within the range that was stated.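

In this assay, putting hydrogen in place of methoxy on an aromatic carbon gives a number 5 percentage points lower from compound 3 to compound 4 (within the scatter), so on this read-out the two compounds cannot be told apart. Set beside the earlier case, the change does not behave measurably differently on the two cores: the same change on two cores in this assay, a number 12 percentage points lower (beyond the scatter) from compound 2 to compound 1 and a number 5 percentage points lower (within the scatter) from compound 3 to compound 4, 7 percentage points apart, within the scatter of two such steps This agreement fits the change carrying over from one core to the other, but it does not prove that it does, since it rests on only two pairs, one of the steps lies within the scatter, and all four compounds sit close to the untreated level at a single concentration.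

The compounds shown leave open whether a different replacement for the methoxy group at this site, such as a hydroxyl group, a chlorine atom or an ethoxy group, would move the number further than hydrogen does. They also leave open whether the same change would look the same at higher concentrations, where a stronger effect would give a larger signal to compare across the two cores.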